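Swapping the Open Diol for a Cyclic Sugar

The source may report more compounds than this note shows. Statements on the series, on what has been measured and on what is new or still open speak of the compounds shown alone.

Compound 3 `O=C1c2c[n+]([O-])c3ccccc3c2C(=O)c2c1c1ccccc1n2Cc1cn(CC(O)CO)nn1` holds the lowest number of the three compounds measured in a toxicity assay on HEK-293T cells (Homo sapiens) for cytotoxicity, read by MTT assay, with a stated time of 72 h (on this read-out higher numbers stand for weaker inhibition and lower numbers for stronger inhibition), where compound 3 gives 760 nM. Compound 2 `O=C1c2c[n+]([O-])c3ccccc3c2C(=O)c2c1c1ccccc1n2Cc1cn(C[C@@H](O)CO)nn1` gives 2030 nM, and compound 1 `O=C1c2c[n+]([O-])c3ccccc3c2C(=O)c2c1c1ccccc1n2Cc1cn([C@H]2C[C@H](O)[C@@H](CO)O2)nn1` gives 3600 nM. The step of a 2.7-fold lower number from compound 2 to compound 3 (0.43 log units; beyond the scatter) separates two drawings of the same atoms and bonds, because of the fact that one of compounds 2 and 3 is drawn with a defined configuration and the other without, at the place where they differ. The step of a 4.7-fold lower number from compound 1 to compound 3 (0.68 log units; beyond the scatter) accompanies the exchange of a cyclic oxolanyl group for the open 2,3-dihydroxypropyl chain, while the step of a 1.8-fold lower number from compound 1 to compound 2 (0.25 log units; within the scatter) covers the same exchange measured against the drawn configuration.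

Compound 4 `O=C1c2c[n+]([O-])c3ccccc3c2C(=O)c2c1c1ccccc1n2Cc1cn([C@H]2O[C@H](CO)[C@@H](O)[C@H]2O)nn1` is not yet measured. It differs from compound 3 in one place: 3,4-dihydroxy-5-(hydroxymethyl)oxolan-2-yl in place of 2,3-dihydroxypropyl on an aromatic nitrogen. Within the data shown here, this change runs opposite to the one between compound 1 and compound 3: there an oxolanyl ring gave way to the open chain, here an oxolanyl ring returns on the same aromatic nitrogen. The steps of a 4.7-fold lower number from compound 1 to compound 3 (0.68 log units; beyond the scatter) and a 1.8-fold lower number from compound 1 to compound 2 (0.25 log units; within the scatter) therefore bear on it most directly, and a modest rise in the number is expected in this assay, not beyond the size of those steps. Compound 4 is estimated to give 2500 nM, with a range from 1000 nM to 6000 nM, which is the expected step of a 3.3-fold higher number from compound 3 to compound 4 (0.52 log units; beyond the scatter).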

Compound 4, half-maximal inhibitory concentration: 1370 nM
Estimate against measurement, compound 4: 1.8-fold (0.26 log units) above; low and high end bracket the measured number.
By their numbers in this assay, from the lowest: compounds 3, 4, 2 and 1 (each within the scatter of the next, the first and the last beyond it).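

In this assay, the oxolanyl ring on this aromatic nitrogen proves not to set the number apart from the open chain, as both comparisons with the 2,3-dihydroxypropyl compounds stay inside the scatter: a 1.8-fold higher number from compound 3 to compound 4 (0.26 log units; within the scatter) and a 1.5-fold lower number from compound 2 to compound 4 (0.17 log units; within the scatter). The larger separation now lies between the two ring compounds, where 3,4-dihydroxy-5-(hydroxymethyl)oxolan-2-yl in place of 4-hydroxy-5-(hydroxymethyl)oxolan-2-yl gives a 2.6-fold lower number from compound 1 to compound 4 (0.42 log units; beyond the scatter), so the gap first seen between compound 1 and the open chain cannot be read as an effect of having a ring at this position. Nothing at hand gives a reason for these steps.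

From the compounds shown here alone, what remains open is how the number in this assay would respond at this aromatic nitrogen to an amine or a carboxylic acid on the oxolanyl ring, or to a longer chain such as 3,4-dihydroxybutyl. The data hold no separate test of the added ring hydroxyl on its own. Also open, going by these compounds, is whether any of these steps would hold in cells other than those of this assay.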